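The source may hold more compounds than are shown below. What is called first, only, known or untested is meant among the compounds shown, and "the series" means these compounds.

In a functional assay on MCF7 cells (Homo sapiens) for inhibition, read by sulforhodamine B assay (a lower number here means a stronger inhibitor, a higher number a weaker inhibitor), compound 1 (`O=C1C(N2CCC2)=CC(=O)c2c1nc1n2[C@H]2OC[C@@H](O)[C@H]2OC1`) gives > 16000 nM, which is a limit of the assay and not a number. Compound 2 (`O=C1C(NC2CCCCC2)=CC(=O)c2c1nc1n2[C@H]2OC[C@@H](O)[C@H]2OC1`) gives > 16000 nM, again a limit. Compound 2 therefore has no number of its own and stands at the limit of > 16000 nM in this assay, at which 2 of the 2 values shown sit, together with compound 1. For the measured compounds named here, the one measured step is a step that the two limits leave unreadable from compound 1 to compound 2 and offers no size to carry forward. Compound 3 (`O=C1C(Nc2cccc(F)c2)=CC(=O)c2c1nc1n2[C@H]2OC[C@@H](O)[C@H]2OC1`) has 3-fluorophenyl in place of cyclohexyl on an amine nitrogen, and the difference is 3-fluorophenyl in place of cyclohexyl on an amine nitrogen in full. With no readable step to lean on, no sizeable shift can be argued for in this assay, and the expected change is an at least 1.1-fold lower number from compound 2 to compound 3 (0.05 log units; that floor lies within the scatter) at the most likely reading. Compound 3 is estimated at 14000 nM with an expected range from 4000 nM to 32000 nM and may well report only a limit once more.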

Compound 3, half-maximal inhibitory concentration: > 4000 nM
Compound 3: a limit, no number (the forecaster's own chance of this, stated with the estimate: 60%); the middle value is on the limit's open side.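

Compound 3 gives only a limit and not a number: the limit of > 4000 nM in this assay, at which 1 of the 3 values shown sits. For the compounds shown here, compound 1 and compound 2 also stand at limits, so no step among the three can be read in this assay. The compounds shown leave open whether any of them has a measurable potency, and how large the change from cyclohexyl to 3-fluorophenyl is.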